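The compounds below may be only part of what the source reports. "The series", "measured", "known", "first", "only" and "open" are said of these compounds alone.

In a functional assay on MDA-MB-231 cells (Homo sapiens) for cytotoxicity, read by ELISA, with a stated time of 2 days (on this read-out lower numbers stand for stronger inhibition and higher numbers for weaker inhibition), compound 1 `Oc1cccc(-c2cc(-c3ccccc3)cc(-c3ccsc3)n2)c1` gives 12100 nM. Compound 2 `Oc1cccc(-c2cc(-c3ccccc3)cc(-c3ccco3)n2)c1` gives 13700 nM, and compound 3 `Oc1cccc(-c2cc(-c3ccccc3)cc(-c3cccc(O)c3)n2)c1` gives 12800 nM. The three values lie within the scatter of one another, so compound 1 cannot be separated from either neighbour.

Compound 4 `Oc1ccc(-c2cc(-c3ccccc3)cc(-c3ccsc3)n2)cc1` keeps the phenyl and thiophen-3-yl groups of compound 1 and differs at one place: 4-hydroxyphenyl in place of 3-hydroxyphenyl on an aromatic carbon. The change is 4-hydroxyphenyl in place of 3-hydroxyphenyl, on an aromatic carbon of a six-membered aromatic ring with 1 nitrogen.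

The measured steps bear on this only indirectly, since each exchanges a different group. a 1.1-fold higher number from compound 1 to compound 2 (0.05 log units; within the scatter) and a 1.1-fold higher number from compound 1 to compound 3 (0.02 log units; within the scatter) both replace thiophen-3-yl, and a 1.1-fold lower number from compound 2 to compound 3 (0.03 log units; within the scatter) replaces furan-2-yl. Among the measured compounds shown here, all three stay within the scatter, but no measured compound carries 4-hydroxyphenyl, so the data do not test this change directly. On the strength of those small steps, no shift beyond the scatter is expected, in either direction, and the expected step is a 1.0-fold lower number from compound 1 to compound 4 (0.00 log units; within the scatter). For compound 4 the estimate is 12000 nM, with an expected range from 5000 nM to 30000 nM.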

Compound 4, half-maximal inhibitory concentration: 5700 nM
For compound 4 the middle estimate is 2.1-fold (0.32 log units) above the measured one; the range from low to high includes it.
By their numbers in this assay, from the lowest: compound 4; then compounds 1, 3 and 2 (each within the scatter of the next).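

In this assay, the hydroxyphenyl group on the aromatic carbon next to the ring nitrogen proves to matter: 4-hydroxyphenyl in place of 3-hydroxyphenyl gives a 2.1-fold lower number from compound 1 to compound 4 (0.33 log units; beyond the scatter) and is a modest change. The earlier steps all exchanged the other aryl group and stayed within the scatter, so this is the first step shown to go beyond it. The two groups have the same heavy atoms, hydrogen-bond donor and acceptor counts and charge, so the shift comes with a change in how the same atoms are joined, not in what is counted.

The compounds shown leave open whether the same exchange would hold with furan-2-yl in place of thiophen-3-yl, and what a methoxy group or an amine would do in place of the hydroxyl of 4-hydroxyphenyl. Nothing given here accounts for the shift.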